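Removing a Fluorine from a Slowly Cleared Benzotriazole

A few compounds are considered here, and "the series" means these few. Any claim that something is new, unique, unknown or untested is made for them only; others in the source may bear on it.

The measured compounds and their values:

compound 1, `Fc1ccc(-c2ccc(Cn3nnc4ccccc43)cc2)c(F)c1`: 0.9 mL/min/g
compound 2, `Fc1cc(Cl)ccc1-c1ccc(Cn2nnc3ccccc32)cn1`: 0.01 mL/min/g

Of the compounds shown here, two sharing a common core have been measured in an ADME assay on microsomes from liver (Homo sapiens) for metabolic stability, tested at 2.5 uM; on this read-out lower numbers stand for slow clearance and higher numbers for fast clearance. In this assay compound 1 gives 0.9 mL/min/g, while compound 2 gives 0.01 mL/min/g. Compound 2 therefore stands at the lowest of the two numbers, and the gap to compound 1 lies well beyond the usual scatter of the measurement.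

The next compound, compound 3, `Clc1ccc(-c2ccc(Cn3nnc4ccccc43)cn2)cc1`, is reached from compound 2 by a single change:

hydrogen in place of fluoro on an aromatic carbon

Among the compounds with values here, no measured pair differs by exactly this change, so there is nothing to read a step from directly. Taken on its own, the loss of the fluoro leaves the rest of compound 2 untouched, and the expectation for the step from compound 2 to compound 3 is a modest rise in clearance, a 5.0-fold higher number from compound 2 to compound 3 (0.70 log units; beyond the scatter), though a result within the scatter would not surprise. Compound 3 is accordingly estimated at 0.05 mL/min/g in this assay, with a range from 0.01 mL/min/g to 0.3 mL/min/g.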

Compound 3, intrinsic clearance in a liver preparation (reported as CLH), per the amount of preparation that the assay uses: 0.2 mL/min/g
Compound 3: the middle estimate sits 4.0-fold (0.60 log units) below what was measured; the range from low to high includes it.
By their numbers in this assay, from the lowest: compound 2; then compound 3; then compound 1.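

Replacing fluoro with hydrogen on an aromatic carbon, ortho to a large group and meta to a chloro group, gives in this assay a 20-fold higher number from compound 2 to compound 3 (1.30 log units; beyond the scatter), a large step that lies beyond the scatter. Within the data shown here, this is the first comparison between compounds that differ in one place, and it shows that this single position can move the clearance read-out by a wide margin, even though the change adds no heavy atom and removes only one, with no ring, charge, donor or acceptor involved. The data fix the size of this step for the 4-chloro-2-fluorophenyl to 4-chlorophenyl change, but nothing available explains why it is so large.

On these data alone, whether a methyl, a methoxy or a nitrile on this same carbon would hold the number as low as fluoro does, or would track hydrogen instead, remains open. As far as these compounds go, compound 1 differs from both of the others in more than one place, so it also remains open whether fluoro at this position would matter as much on the core of compound 1.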